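The source may hold more compounds than are shown below. What is called first, only, known or untested is meant among the compounds shown, and "the series" means these compounds.

In a functional assay on AGS cells (Homo sapiens) for inhibition, read by MTT assay, with a stated time of 72 h (a lower number here means a stronger inhibitor, a higher number a weaker inhibitor), compound 1 `Cc1ccc(C(=O)Nc2ccc(CNC(=O)OCc3cccnc3)cc2)c(N2CCCC2)c1` is one of three compounds with a result. Compound 1 gives > 100000 nM, which is a limit of the assay rather than a number. Compound 2 `COc1ccc(N2CCCC2)c(C(=O)Nc2ccc(CNC(=O)OCc3cccnc3)cc2)c1` gives 25600 nM in this assay. Compound 3 `O=C(NCc1ccc(NC(=O)c2cccc(F)c2N2CCCC2)cc1)OCc1cccnc1` gives > 100000 nM, again a limit and not a number. Compound 1 thus sits at the limit of > 100000 nM in this assay, at which 2 of the 3 values shown sit, so its standing against compound 2 can be told only as far as that limit allows. Compound 4 `O=C(NCc1ccc(NC(=O)c2ccc(F)cc2N2CCCC2)cc1)OCc1cccnc1` has no result yet in this assay. It differs from compound 1 by fluoro in place of methyl on an aromatic carbon: the methyl leaves and a fluoro enters, on an aromatic carbon of a six-membered aromatic ring of carbon only, meta to a pyrrolidin-1-yl group and para to a large group. Among the measured compounds shown here, no measured pair shows this exact change. Compound 3 carries a fluoro on a different aromatic carbon and reaches only a limit in this assay, which gives no hint of a gain. For the step from compound 1 to compound 4 a change of a number no higher from compound 1 to compound 4 (the limit leaves the size open) is expected, none beyond the scatter. Compound 4 is therefore estimated to give about 100000 nM, within 30000 nM to 300000 nM.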

Compound 4, half-maximal inhibitory concentration: > 100000 nM
Compound 4 gave a limit, no number; the forecaster's own chance of this, stated with the estimate: 60%; the middle value lies on the limit itself.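

In this assay compound 1 and compound 4 each give a limit and not a number, so the step between them cannot be read: the limit of > 100000 nM in this assay, at which 3 of the 4 values shown sit. The compounds shown leave open whether this single change in structure alters inhibition at all.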